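This account rests on a few compounds, and the source may have more. Where it says the series, first, only, none or still open, it means among the compounds named here.

In a functional assay on Raji cells (Homo sapiens) for cytotoxicity, read by CCK-8 assay, with a stated time of 24 h (a lower number here means a stronger inhibitor, a higher number a weaker inhibitor), compound 1 `C=CC(=O)N1C(=O)CC(C)Sc2ccccc21` gives 837000 nM and so stands as the weaker of the two measured compounds. Compound 2 `C=CC(=O)N1C(=O)CC(c2ccc([N+](=O)[O-])cc2)Sc2ccccc21` gives 34800 nM on the shared core, the lower number of the two, and the gap between them lies beyond the usual scatter. Compound 3 `C=CC(=O)N1C(=O)CC(c2ccc(C#N)cc2)Sc2ccccc21` still awaits measurement. It departs from compound 2 in one place, with cyano in place of nitro on an aromatic carbon, para to a large group cyano in place of nitro on an aromatic carbon and nothing else altered. Going by the values given here, no measured pair shows this swap, and two measured compounds give no direct guide to its size. In this assay a small step is expected, most likely none beyond the scatter, with a slight lean toward a higher number. The estimated change a 1.3-fold higher number from compound 2 to compound 3 (0.11 log units; within the scatter) is accordingly modest. For compound 3 the estimated value is 45000 nM within an expected range of 18000 nM to 110000 nM once it is measured.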

Compound 3, half-maximal inhibitory concentration: 84500 nM
The estimate for compound 3 lay 1.9-fold (0.27 log units) below the measured number, and the stated range covers the measured number.
By their numbers in this assay, from the lowest: compound 2; then compound 3; then compound 1.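

In this assay the change of nitro to cyano on an aromatic carbon, para to a large group, gives a 2.4-fold higher number from compound 2 to compound 3 (0.39 log units; beyond the scatter) and so shows that this position is not indifferent to which of these two groups it carries. The step of 4-cyanophenyl in place of methyl on a saturated ring carbon, a 9.9-fold lower number from compound 1 to compound 3 (1.00 log units; beyond the scatter), shows that the lower number seen with the nitro-bearing ring in compound 2 is not tied to nitro alone. No measurement here explains why the nitro compound gives the lower number of the pair.

Going by these compounds alone, with only two groups compared at this position, no trend can be drawn from them. An amine, a carboxylic acid or a plain unsubstituted phenyl ring could each fall on either side of these values, and the compounds shown do not tell which.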